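The source may hold more compounds than are shown below. What is called first, only, known or untested is meant among the compounds shown, and "the series" means these compounds.

Measured compounds:
Compound 1 `N#Cc1cccc(NC(=O)c2cc(C(F)(F)F)ccc2OCc2ccc(F)cc2)c1`: 7.94 nM
Compound 2 `CN1CCC(c2ccc(OCc3ccccc3)c(C(=O)Nc3ccnnc3)c2)CC1`: 20 nM
Compound 3 `O=C(Nc1cccnc1)c1cc(C(F)(F)F)ccc1OCc1ccccc1`: 12.6 nM

Three compounds share a core in which an aryl amide carries a benzyloxy group. In an assay on Sf9 cells for inhibition of Leucine-rich repeat serine/threonine-protein kinase 2 (Homo sapiens), read by TR-FRET, with stated times of 30 min and 2 h (a lower number here means a stronger inhibitor, a higher number a weaker inhibitor), compound 1 gives 7.94 nM, compound 3 gives 12.6 nM, and compound 2 gives 20 nM. Compound 2 therefore carries the highest of the three numbers; its gap to compound 3 lies within the usual scatter, while compound 1 sits beyond the scatter with a lower number.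

Compound 4 `N#CC1CCN(c2ccc(OCc3ccccc3)c(C(=O)Nc3ccnnc3)c2)CC1` has not yet been measured. It differs from compound 2 in one place: 4-cyanopiperidin-1-yl in place of 1-methylpiperidin-4-yl on an aromatic carbon. Among the measured compounds shown here, no measured pair shows this kind of change, so there is no step on record to lean on; the account rests on compound 2 alone. The expected step is small, with the number of compound 4 estimated to drift only slightly upward, not beyond the scatter, as a 1.3-fold higher number from compound 2 to compound 4 (0.10 log units; within the scatter). In this assay compound 4 is estimated at 25 nM, with a plausible range from 8 nM to 80 nM.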

Compound 4, half-maximal inhibitory concentration: 10 nM
Compound 4: middle estimate off by 2.5-fold (0.40 log units), on the high side; the range from low to high includes it.
By their numbers in this assay, from the lowest: compounds 1, 4, 3 and 2 (each within the scatter of the next, the first and the last beyond it).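

In this assay, among the compounds shown here, the exchange of 1-methylpiperidin-4-yl for 4-cyanopiperidin-1-yl gives a 2.0-fold lower number from compound 2 to compound 4 (0.30 log units; within the scatter) and is the first one-place step on record in this set, on the aromatic carbon para to a benzyloxy group. This place therefore carries either six-membered ring, one with a nitrile and one without, with no difference beyond the usual scatter, so the exchange does not separate compound 2 from compound 4 in this assay. No measurement here bears on what lies behind the step.

From the compounds shown here alone, it remains open how a primary amine or a carboxylic acid in place of the nitrile would read, or a morpholine in place of the piperidine ring. Going by these compounds, it also remains open whether the same exchange would read alike with the amide of compound 3 in place of the (pyridazin-4-yl)carbamoyl group.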